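Swapping a propyl for a dimethylamino on an aryl ring

The source may hold more compounds than are shown below. What is called first, only, known or untested is meant among the compounds shown, and "the series" means these compounds.

Measured so far:
compound 1 `O=C1NNC(=O)C2(CSC3=C2C(=O)c2ncccc2C3=O)N1` with 1050 nM
compound 2 `CCCc1ccc(N2C(=O)NC3(CSC4=C3C(=O)c3ncccc3C4=O)C2=O)cc1` with 1 nM

Of the compounds shown here, two share a core and have been tested in a functional assay on ACHN cells (Homo sapiens) for antiproliferative activity, read by MTT assay, with a stated time of 96 h; a lower number here means a stronger inhibitor, a higher number a weaker inhibitor. Compound 1 `O=C1NNC(=O)C2(CSC3=C2C(=O)c2ncccc2C3=O)N1` gives 1050 nM. Compound 2 `CCCc1ccc(N2C(=O)NC3(CSC4=C3C(=O)c3ncccc3C4=O)C2=O)cc1`, which carries a 4-propylphenyl group on the shared core, gives 1 nM and stands lowest of the two numbers, with compound 1 far above it, a gap well beyond the scatter. Compound 3 `CN(C)c1ccc(N2C(=O)NC3(CSC4=C3C(=O)c3ncccc3C4=O)C2=O)cc1` has not been measured yet. It differs from compound 2 in one place: dimethylamino in place of propyl on an aromatic carbon. Nothing in the measured pair shows what this exchange on the aryl ring does, so only a modest step in this assay is expected, more likely toward a somewhat higher number than a lower one. The step from compound 2 to compound 3 is estimated as a 3.0-fold higher number from compound 2 to compound 3 (0.48 log units; beyond the scatter). For compound 3 the expected value is 3 nM, within a range from 0.5 nM to 25 nM.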

Compound 3, half-maximal inhibitory concentration: 90 nM
Compound 3: the middle estimate sits 30-fold (1.48 log units) below what was measured, outside the stated range (above it).
By their numbers in this assay, from the lowest: compound 2; then compound 3; then compound 1.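

In this assay, this position on the aryl ring proves highly sensitive to the group it carries: replacing 4-propylphenyl with 4-(dimethylamino)phenyl gives a 90-fold higher number from compound 2 to compound 3 (1.95 log units; beyond the scatter) and so costs much of the activity. Propyl and dimethylamino have the same number of heavy atoms, so matching that count does not preserve the activity; what differs is that a nitrogen replaces a carbon and a hydrogen-bond acceptor enters. No measurement shown here explains the size of this step.

The compounds shown leave open whether the nitrogen itself matters or how the exact arrangement of the group contributes, which a comparison with isopropyl or with an ethylamino group could begin to separate. They also leave open how a longer chain, such as butyl, would behave at this position.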